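The compounds below may be only part of what the source reports. "The series", "measured", "known", "first", "only" and "open" are said of these compounds alone.

Of the compounds shown here, three built on one shared core have been tested in an assay on HEK293 cells for displacement of a labelled ligand from NPC1-like intracellular cholesterol transporter 1 (Homo sapiens); on this read-out higher numbers stand for weaker inhibition and lower numbers for stronger inhibition. Compound 1 `CC(C)(C)c1ccc(C(=O)N2CCC3(CC2)C(=O)N(CC(=O)N2CCC(CCO)CC2)CN3c2ccccc2)cc1` gives 2600 nM. Compound 2 `CC(C)(C)c1ccc(C(=O)N2CCC3(CC2)C(=O)N(CC(=O)NCCN)CN3c2ccccc2)cc1` gives 7000 nM, and the change between them brought a 2.7-fold higher number from compound 1 to compound 2 (0.43 log units; beyond the scatter). Compound 3 `CC(C)(C)c1ccc(C(=O)N2CCC3(CC2)C(=O)N(CC(=O)NCCCCNS(C)(=O)=O)CN3c2ccccc2)cc1` gives 4500 nM; among the three numbers it stands second highest, with compound 2 nearest at a 1.6-fold lower number from compound 2 to compound 3 (0.19 log units; within the scatter) and compound 1 furthest at a 1.7-fold higher number from compound 1 to compound 3 (0.24 log units; within the scatter), both within the scatter.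

Compound 4 `CC(C)(C)c1ccc(C(=O)N2CCC3(CC2)C(=O)N(CC(=O)NCCCNS(C)(=O)=O)CN3c2ccccc2)cc1` differs from compound 3 in a single place: methanesulfonamido in place of (methanesulfonamido)methyl on a saturated chain carbon, three bonds along the chain from an amide-type nitrogen. Among the compounds with values here, only one measured step speaks to this end of the chain: putting 2-(methanesulfonamido)ethyl in place of amino on a saturated chain carbon, two bonds along the chain from an amide-type nitrogen, moved the number no further than the scatter allows. Trimming that same chain while keeping its methanesulfonamido end is therefore expected to leave this assay's number essentially where compound 3 sits, with no step beyond the scatter in either direction. Compound 4 is accordingly estimated at 4500 nM, with a range from 2200 nM to 9000 nM, which amounts to an expected no change at the digits printed from compound 3 to compound 4 (within the scatter).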

Compound 4, half-maximal inhibitory concentration: 10400 nM
Compound 4: the middle estimate sits 2.3-fold (0.36 log units) below what was measured, and the stated range ends below it.
By their numbers in this assay, from the lowest: compounds 1, 3, 2 and 4 (each within the scatter of the next, the first and the last beyond it).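

In this assay, within the data shown here, trimming the chain from 4-(methanesulfonamido)butyl to 3-(methanesulfonamido)propyl gives a 2.3-fold higher number from compound 3 to compound 4 (0.36 log units; beyond the scatter), so chain length matters here even with the methanesulfonamido end kept, which no earlier step could show. The shorter chain cannot be told apart from the plain amine of compound 2, at a 1.5-fold higher number from compound 2 to compound 4 (0.17 log units; within the scatter), but it falls clearly short of the 4-(2-hydroxyethyl)piperidin-1-yl amide, with a 4.0-fold higher number from compound 1 to compound 4 (0.60 log units; beyond the scatter), the widest step in this set. Nothing shown gives a reason for the effect of chain length.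

As far as these compounds go, whether a longer chain, such as 5-(methanesulfonamido)pentyl, would lower the number further remains open. So does whether another end group on the butyl chain, such as a carboxylic acid or an acetamide, would match compound 3.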